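Adding two hydroxyl arms to the ether chain of compound 3

The source may hold more compounds than are shown below. What is called first, only, known or untested is meant among the compounds shown, and "the series" means these compounds.

Of the compounds shown here, three from one series have been measured in an assay for inhibition of serine/threonine-protein kinase Sgk1 (Homo sapiens), with stated times of 30 min and 60 min, in the presence of a further agent that is not named here; on this read-out higher numbers stand for weaker inhibition and lower numbers for stronger inhibition. Compound 1 `CNC(=O)c1cc(-c2ccc(NS(=O)(=O)c3cccc(Cl)c3Cl)cc2)nc2[nH]ncc12` gives 929 nM. For the measured compounds named here, compound 2 `CN1CCC(CNC(=O)c2cc(-c3ccc(NS(=O)(=O)c4cccc(Cl)c4Cl)cc3)nc3[nH]ncc23)C1` gives 45 nM, and the single one-place step from compound 1 to compound 2 is a 21-fold lower number from compound 1 to compound 2 (1.31 log units; beyond the scatter). Compound 3 `CCOc1nc(-c2ccc(NS(=O)(=O)c3cc(Cl)ccc3F)cc2)nc2[nH]nc(C)c12` gives 183 nM, which places it second highest of the three: compound 2 shows a lower number and compound 1 a higher one, both gaps lying beyond the scatter.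

Compound 4 `Cc1n[nH]c2nc(-c3ccc(NS(=O)(=O)c4cc(Cl)ccc4F)cc3)nc(OCC(CO)CO)c12` differs from compound 3 by 2-hydroxy-1-(hydroxymethyl)ethyl in place of methyl on a saturated chain carbon bound to an oxygen on an aromatic ring. Going by the values given here, no measured step concerns this part of the molecule; the only known step, from compound 1 to compound 2, alters a chain on an amide nitrogen in a different core, so it offers no direct guide. With nothing to point either way, the expectation is a step of a 1.0-fold lower number from compound 3 to compound 4 (0.01 log units; within the scatter) in this assay, which is no change beyond the scatter. Compound 4 is therefore estimated at 180 nM, within a range from 50 nM to 650 nM.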

Compound 4, half-maximal inhibitory concentration: 2 nM
Beside the measured number, compound 4's estimate is 90-fold (1.95 log units) above it; measured number below the stated range.
By their numbers in this assay, from the lowest: compound 4; then compound 2; then compound 3; then compound 1.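

Putting 2-hydroxy-1-(hydroxymethyl)ethyl in place of methyl on the ether chain gives a 92-fold lower number from compound 3 to compound 4 (1.96 log units; beyond the scatter) in this assay, showing that this chain, untouched by the earlier step, is a place where a single change can shift the number strongly. The entering group carries 5 heavy atoms, 2 hydrogen-bond donors and 2 hydrogen-bond acceptors, so added size and added hydroxyl groups arrive together, and this one step cannot tell their contributions apart. Nothing measured here explains the size of this step.

The compounds shown leave open whether one hydroxyl group would serve as well as two, or whether the added carbons alone matter. A 2-hydroxyethyl group, a plain isobutyl chain or an amine at this place would speak to those questions.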